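Two Halogenated Pyridines on a Shared Core

The compounds below may be only part of what the source reports. "The series", "measured", "known", "first", "only" and "open" are said of these compounds alone.

Compound 2 `O=C(O)Cc1sc(C(c2ccc(F)cc2)c2ccc(F)cc2)nc1-c1ccnc(Cl)c1`: 39 nM
Compound 1 `O=C(O)Cc1sc(C(c2ccc(F)cc2)c2ccc(F)cc2)nc1-c1ccoc1`: 130 nM

Of the compounds shown here, two have been measured in an in vitro functional assay on HEK285-7 cells for antagonist activity at prostaglandin D2 receptor 2 (Homo sapiens), read by BRET and beta-arrestin recruitment; a lower number here means a stronger inhibitor, a higher number a weaker inhibitor. Compound 2 gives 39 nM and stands at the lowest of the two numbers; its nearest neighbour is compound 1, which gives 130 nM. Among the compounds with values here, the only step between measured compounds, a 3.3-fold lower number from compound 1 to compound 2 (0.52 log units; beyond the scatter), is modest and lies beyond the scatter.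

Compound 3 `O=C(O)Cc1sc(C(c2ccc(F)cc2)c2ccc(F)cc2)nc1-c1cc(F)nc(F)c1` has not yet been measured. It differs from compound 2 in one place: 2,6-difluoropyridin-4-yl in place of 2-chloropyridin-4-yl on an aromatic carbon. Within the data shown here, both groups are pyridin-4-yl rings carrying halogen, so the change is smaller in kind than the one from compound 1 to compound 2, which exchanged a furan-3-yl for a 2-chloropyridin-4-yl. Among the measured compounds shown here, no measured step tells how a second halogen on this ring, or fluorine in place of chlorine, shifts the number; the step of a 3.3-fold lower number from compound 1 to compound 2 (0.52 log units; beyond the scatter) bears on it only in showing that a halogenated pyridine at this carbon is tolerated. Compound 3 is therefore expected to give about 50 nM in this assay, with a range from 18 nM to 150 nM, which means an estimated step of a 1.3-fold higher number from compound 2 to compound 3 (0.11 log units; within the scatter) from compound 2 to compound 3, not clearly beyond the scatter.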

Compound 3, half-maximal inhibitory concentration: 110 nM
For compound 3 the middle estimate is 2.2-fold (0.34 log units) below the measured one; the measured number falls inside the stated range.
By their numbers in this assay, from the lowest: compound 2; then compounds 3 and 1 (each within the scatter of the next).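

In this assay, the halogens on the pyridin-4-yl ring at this carbon matter: 2,6-difluoropyridin-4-yl in place of 2-chloropyridin-4-yl gives a 2.8-fold higher number from compound 2 to compound 3 (0.45 log units; beyond the scatter), so the lower number seen earlier does not extend to every halogenated pyridine placed next to the ring nitrogen. Furan-3-yl and 2,6-difluoropyridin-4-yl, by contrast, cannot be told apart at this position, with a 1.2-fold lower number from compound 1 to compound 3 (0.07 log units; within the scatter), which leaves the 2-chloropyridin-4-yl group of compound 2 as the only one of the three whose number stands clear of both others. Nothing at hand offers an explanation for either step.

The change from compound 2 to compound 3 alters two things at once, the kind of halogen and the number of halogens on the ring, and the compounds shown do not separate these two contributions. On these data alone, a 2-fluoropyridin-4-yl group would isolate the exchange of chlorine for fluorine and a 2,6-dichloropyridin-4-yl group the addition of a second chlorine, while it also remains open whether a methyl group or an amine could take the place of the chlorine of compound 2.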